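The source may report more compounds than this note shows. Statements on the series, on what has been measured and on what is new or still open speak of the compounds shown alone.

Three related compounds have been tested so far in an ADME assay on microsomes from liver (Mus musculus) for metabolic stability (a lower number here means slower removal, a higher number faster removal of the compound), and their numbers spread widely. Compound 1 `CN(C)c1noc(-c2cccc(CN(C)c3ccc4[nH]nc(C(=O)O)c4c3)c2O)n1` gives 46 mL/min/kg, compound 2 `CN(C)c1noc(-c2cccc(CNc3ccc4[nH]nc(C(=O)O)c4c3)c2)n1` gives 2.9 mL/min/kg, and compound 3 `CN(C)c1noc(-c2cccc(CNc3cnc4nn[nH]c4c3)c2O)n1` gives 1210 mL/min/kg. Compound 1 therefore holds the middle place of the three, and its gaps to both of the others lie beyond the usual scatter of repeated measurements. No two of these compounds differ in one place only, so none of these gaps shows what a single swap of one group does.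

The next compound to be measured, compound 4 `CC(C)c1csc(-c2cccc(CN(C)c3ccc4[nH]nc(C(=O)O)c4c3)c2O)n1`, keeps the core of compound 1 and changes one group: 4-isopropyl-1,3-thiazol-2-yl in place of 3-(dimethylamino)-1,2,4-oxadiazol-5-yl on an aromatic carbon. The swap sits on an aromatic carbon of a six-membered aromatic ring of carbon only, ortho to a hydroxy group. Within the data shown here, with no measured pair to guide this change, the best starting point is compound 1 itself at 46 mL/min/kg, and the wide spread of the series argues for a broad range. A small rise that stays within the scatter is expected, and the estimated step is a 1.5-fold higher number from compound 1 to compound 4 (0.18 log units; within the scatter). For compound 4 the expected value in this assay is 70 mL/min/kg, with an estimated range of 20 mL/min/kg to 250 mL/min/kg.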

Compound 4, clearance: 13 mL/min/kg
For compound 4 the middle estimate is 5.4-fold (0.73 log units) above the measured one; measured number below the stated range.
By their numbers in this assay, from the lowest: compound 2; then compound 4; then compound 1; then compound 3.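

In this assay, among these compounds, putting 4-isopropyl-1,3-thiazol-2-yl in place of 3-(dimethylamino)-1,2,4-oxadiazol-5-yl gives a 3.5-fold lower number from compound 1 to compound 4 (0.55 log units; beyond the scatter) and this is the only step that comes from a change in one place. It shows that this position, on an aromatic carbon ortho to a hydroxy group, responds to what is placed there: both groups have the same count of heavy atoms and each is a five-membered aromatic ring, yet their numbers lie apart by more than the usual scatter, with the entering group carrying fewer hetero atoms and fewer hydrogen-bond acceptors. Nothing measured here accounts for the step or ties it to any one feature of the new group.

The compounds shown leave open whether the ring or the isopropyl group carries the step, a question that a 1,3-thiazol-2-yl bearing a methyl group or a carboxylic acid in place of isopropyl could help to answer. They also leave open whether the same swap would give a step of similar size on a different core, such as that of compound 3.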